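Naphthalen-2-yl in place of 4-(tert-butyl)phenyl: an expected small step

The source may hold more compounds than are shown below. What is called first, only, known or untested is meant among the compounds shown, and "the series" means these compounds.

Compound 1 (`Cc1ccc(CN2CCc3ncn(COCc4ccccc4)c3/C(=C/c3ccccc3)C2=O)cc1`) in a functional assay on A549 cells (Homo sapiens) for inhibition, read by MTT assay, with a stated time of 72 h (a lower number here means a stronger inhibitor, a higher number a weaker inhibitor), gives 11400 nM
Compound 2 (`CC(C)(C)c1ccc(CN2CCc3ncn(COCc4ccccc4)c3/C(=C/c3ccccc3)C2=O)cc1`) in this assay gives 20600 nM

These two numbers lie within the scatter of each other, so compound 2 (20600 nM) has no clear rank against compound 1. Compound 3 (`O=C1/C(=C\c2ccccc2)c2c(ncn2COCc2ccccc2)CCN1Cc1ccc2ccccc2c1`) has not yet been measured. It differs from compound 2 in one place (naphthalen-2-yl in place of 4-(tert-butyl)phenyl on a saturated chain carbon bound to an amide-type nitrogen in a ring): naphthalen-2-yl stands in place of 4-(tert-butyl)phenyl on a saturated chain carbon bound to an amide-type nitrogen in a ring.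

Among the compounds with values here, only one measured step bears on this change, and it lies within the group that now leaves: tert-butyl in place of methyl on an aromatic carbon. Since that swap stayed within the scatter (a 1.8-fold higher number from compound 1 to compound 2 (0.26 log units; within the scatter)), no step beyond the scatter is expected in this assay, and no firm direction either. Within the data shown here, one step is thin evidence, and no compound with naphthalen-2-yl has a number yet, so the range stays wide. Compound 3 is estimated at 15000 nM, with an expected range from 6000 nM to 35000 nM. The expected step is small (a 1.4-fold lower number from compound 2 to compound 3 (0.14 log units; within the scatter)).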

Compound 3, half-maximal inhibitory concentration: 26400 nM
Estimate against measurement, compound 3: 1.8-fold (0.25 log units) below, and the stated range covers the measured number.
By their numbers in this assay, from the lowest: compounds 1, 2 and 3 (each within the scatter of the next, the first and the last beyond it).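

Naphthalen-2-yl and 4-(tert-butyl)phenyl have the same count of 10 heavy atoms, all carbon, but naphthalen-2-yl has two six-membered aromatic rings rather than one, and in this assay this exchange gives a 1.3-fold higher number from compound 2 to compound 3 (0.11 log units; within the scatter). So at this saturated chain carbon bound to an amide-type nitrogen in a ring, a second aromatic ring in place of the tert-butyl group brings no measurable difference. Within the data shown here, the same position does, however, give the first step beyond the scatter, a 2.3-fold higher number from compound 1 to compound 3 (0.36 log units; beyond the scatter), when naphthalen-2-yl replaces 4-methylphenyl; that step is modest, and compound 2 lies within the scatter of both other compounds. No other measurement bears on these results, so the data offer no explanation for them.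

On these data alone, all three groups at this position consist only of carbon and hydrogen, so the effect of an amine, a carboxylic acid or a pyridine ring there remains open. Also open, as far as these compounds go, is whether these small steps would hold if the benzyloxymethyl or benzylidene part of the shared core were replaced.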